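The compounds below may be only part of what the source reports. "The series", "measured", "known", "first", "only" and "open" are said of these compounds alone.

Measured compounds:
Compound 1 `CCC(C)(C)Cc1c[nH]c(CCc2ccc(-c3ccc(F)cn3)cc2)n1` gives 105 nM in a functional assay on HEK293 cells for agonist activity at Bombesin receptor subtype-3 (Mus musculus), read by luminescence and calcium flux, with a stated time of 10 min; a higher number here means that more compound is needed for the effect, a lower number that less compound is needed.
Compound 2 `CCC(C)(C)Cc1c[nH]c(CCc2ccc(-c3cccnc3C(=O)O)cc2)n1` gives 97 nM in this assay.

Compound 2 has the lower of the two numbers, but its gap to compound 1 is small: a 1.1-fold lower number from compound 1 to compound 2 (0.03 log units; within the scatter). So the two measured compounds sit together, and nothing separates them beyond the scatter.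

Compound 3 `CCC(C)(C)Cc1c[nH]c(CCc2ccc(-c3ccns3)cc2)n1` is not yet measured. It differs from compound 2 in one place: 1,2-thiazol-5-yl in place of 2-carboxypyridin-3-yl on an aromatic carbon. Among the measured compounds shown here, the only measured step that bears on this change is the one at the same aromatic carbon, from compound 1 to compound 2, where one six-membered aromatic ring replaced another with no change beyond the scatter. For the measured compounds named here, that step speaks for tolerance of different aromatic groups at this position, but neither measured compound carries a five-membered ring there, so no measured step covers the change directly. Compound 3 is therefore expected to stay near compound 2 in this assay, with a step of a 1.5-fold higher number from compound 2 to compound 3 (0.19 log units; within the scatter), and its number is estimated at 150 nM, within 50 nM to 500 nM.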

Compound 3, half-maximal effective concentration: 103 nM
Compound 3: middle estimate off by 1.5-fold (0.16 log units), on the high side; the measured number falls inside the stated range.
By their numbers in this assay, from the lowest: compounds 2, 3 and 1 (each within the scatter of the next).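

In this assay, this aromatic carbon of the six-membered aromatic ring of carbon only also accepts a five-membered aromatic ring, something neither earlier compound tested: the change from 2-carboxypyridin-3-yl to 1,2-thiazol-5-yl gives no shift beyond the scatter (a 1.1-fold higher number from compound 2 to compound 3 (0.03 log units; within the scatter)). The same holds when 1,2-thiazol-5-yl replaces 5-fluoropyridin-2-yl (a 1.0-fold lower number from compound 1 to compound 3 (0.01 log units; within the scatter)). Ring size, a sulfur atom and the hydrogen-bond donor of the carboxyl group therefore come and go here without separating the three compounds, and no measurement on hand explains this tolerance.

As far as these compounds go, whether an open-chain amine, a morpholine ring or a simple phenyl ring at this carbon would move the number beyond the scatter stays open. The compounds shown also leave open how far any change to the shared core would matter.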